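A few compounds are considered here, and "the series" means these few. Any claim that something is new, unique, unknown or untested is made for them only; others in the source may bear on it.

Compound 1, `COc1ccc(-c2ssc(=S)c2-c2cc(OC)c(OC)c(OC)c2)cc1[N+](=O)[O-]`, gives 13600 nM in a functional assay on SGC-7901 cells (Homo sapiens) for antiproliferative activity, read by MTT assay, with a stated time of 72 h; a lower number here means a stronger inhibitor, a higher number a weaker inhibitor. Compound 2, `COc1ccc(-c2ssc(=S)c2-c2cc(OC)c(OC)c(OC)c2)cc1N`, carries one change against it: amino in place of nitro on an aromatic carbon. In this assay compound 2 gives 444 nM, so the step of a 31-fold lower number from compound 1 to compound 2 (1.49 log units; beyond the scatter) is the largest single movement seen in this set.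

Compound 3, `COc1ccc(-c2c(-c3cc(OC)c(OC)c(OC)c3)ssc2=S)cc1[N+](=O)[O-]`, is built from the same atoms as compound 1 joined differently; the difference between the two cores is not broken down here. In this assay compound 3 gives 44700 nM, the highest of the three numbers, with compound 1 as its nearest neighbour and compound 2 as its furthest.

Compound 4, `COc1ccc(-c2c(-c3cc(OC)c(OC)c(OC)c3)ssc2=S)cc1N`, is not yet measured. Against compound 3 it carries amino in place of nitro on an aromatic carbon, the same change in the same surroundings as the one from compound 1 to compound 2. On the strength of that earlier step a 31-fold lower number from compound 1 to compound 2 (1.49 log units; beyond the scatter) alone, one change seen once, a step of similar direction and size, a 25-fold lower number from compound 3 to compound 4 (1.40 log units; beyond the scatter), is expected in this assay. Compound 4 is therefore estimated to give about 1800 nM, most likely between 500 nM and 8000 nM.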

Compound 4, half-maximal inhibitory concentration: 2620 nM
The estimate for compound 4 lay 1.5-fold (0.16 log units) below the measured number, and the stated range covers the measured number.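

In this assay, amino in place of nitro gave a 17-fold lower number from compound 3 to compound 4 (1.23 log units; beyond the scatter), so the change lowered the number on both cores, and the two steps agree in size as closely as the scatter allows: the same change on two cores in this assay, a 31-fold lower number (1.49 log units; beyond the scatter) from compound 1 to compound 2 and a 17-fold lower number (1.23 log units; beyond the scatter) from compound 3 to compound 4, 1.8-fold (0.25 log units) apart, within the scatter of two such steps. Within these four compounds, the step therefore carried over from the core of compound 1 to the core of compound 3 with no difference that can be told from scatter. For the compounds shown here, it rests on only two pairs, however, and it shows neither that the step would hold on a further core or with other groups on the same ring, nor why the amino compounds give the lower numbers.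

The compounds shown leave open whether a hydroxyl group, a methylamino group or an acetamide in the same place would give numbers closer to those of the amino compounds or the nitro compounds. They also leave open whether the step would persist in any other assay.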